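Notes on a carbonyl substituent change in the series

The compounds below may be only part of what the source reports. "The series", "measured", "known", "first", "only" and "open" are said of these compounds alone.

Measured so far:
compound 1 `Cc1cc(C(=O)O)nn1C(C)c1cc(Cl)ccc1OCc1ccccc1` — 10 nM
compound 2 `Cc1cc(C(=O)NN2CCCCC2)nn1Cc1cc(Cl)ccc1OCC(C)C` — 200 nM
compound 3 `Cc1cc(NC(=O)C(C)C)nn1Cc1cc(Cl)ccc1OCc1ccccc1` — 25.1 nM

All three values come from an assay on CHO-K1 cells for displacement of a labelled ligand from prostaglandin E2 receptor EP1 subtype (Homo sapiens); a lower number here means a stronger inhibitor, a higher number a weaker inhibitor. Compound 3 stands second highest of the three; compound 1 gives 10 nM, a lower number beyond the scatter, while compound 2 gives 200 nM, a higher number further away.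

Compound 4 `COC(=O)Nc1cc(C)n(Cc2cc(Cl)ccc2OCc2ccccc2)n1` is not yet measured. It differs from compound 3 in one place: methoxy in place of isopropyl on a carbonyl carbon. The (isopropylcarbonyl)amino group becomes a (methoxycarbonyl)amino group.

Among the compounds with values here, no measured pair shows this change, so the expected step of a 1.2-fold higher number from compound 3 to compound 4 (0.08 log units; within the scatter) is small, within the scatter, in no fixed direction. Compound 4 is therefore estimated at 30 nM, with a range from 10 nM to 90 nM.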

Compound 4, half-maximal inhibitory concentration: 200 nM
The estimate for compound 4 lay 6.7-fold (0.82 log units) below the measured number, outside the stated range (above it).
By their numbers in this assay, from the lowest: compound 1; then compound 3; then compounds 2 and 4 (each within the scatter of the next).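

In this assay the substituent on the carbonyl carbon matters: methoxy in place of isopropyl gives an 8.0-fold higher number from compound 3 to compound 4 (0.90 log units; beyond the scatter) as the first step read at this position. The (isopropylcarbonyl)amino group therefore goes with the lower number, though this rests on a single pair. Nothing available bears on the cause of this step.

Still open, on these data alone, is how an ethyl group, a tert-butyl group or an amine on the same carbonyl carbon would compare. As far as these compounds go, whether the step carries over to other substituents on the shared core also remains unknown.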